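A Pyridin-4-yl Variant of Compound 3: Expected Binding

The compounds below may be only part of what the source reports. "The series", "measured", "known", "first", "only" and "open" are said of these compounds alone.

Measured so far, in an in vitro assay on HEK385-7 cells for displacement of a labelled ligand from prostaglandin D2 receptor 2 (Homo sapiens); on this read-out lower numbers stand for stronger inhibition and higher numbers for weaker inhibition:
- compound 1, `O=C(O)Cc1sc(COc2ccc(Cl)cc2)nc1-c1ccc(Cl)cc1`, gives 32 nM
- compound 3, `O=C(O)Cc1sc(C(c2ccc(F)cc2)c2ccc(F)cc2)nc1-c1ccccc1`, gives 16 nM
- compound 2, `Nc1nc(-c2ccc(Cl)cc2)c(CC(=O)O)s1`, gives > 100000 nM

For compound 2 the value is a limit of this assay, not a number. Of the two numbers that remain, compound 3 carries the one that stands lowest, but compound 1 lies within the usual scatter of it, so the two cannot be told apart on these data. Going by the values given here, no pair of measured compounds differs in one place only, so no measured step is available to lean on.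

Compound 4, `O=C(O)Cc1sc(C(c2ccc(F)cc2)c2ccc(F)cc2)nc1-c1ccncc1`, is the next compound to be measured. It differs from compound 3 in one place: pyridin-4-yl in place of phenyl on an aromatic carbon. Among the compounds with values here, nothing among the measured compounds shows how such a swap moves the result in this assay. The expectation is therefore a step of a 2.2-fold higher number from compound 3 to compound 4 (0.34 log units; beyond the scatter) that stays close to the scatter, leaning slightly toward a higher number. Compound 4 is estimated at 35 nM, with a range from 10 nM to 130 nM.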

Compound 4, half-maximal inhibitory concentration: 5.3 nM
The estimate for compound 4 lay 6.6-fold (0.82 log units) above the measured number; the whole stated range lies above it.
By their numbers in this assay, from the lowest: compound 4; then compounds 3 and 1 (each within the scatter of the next). At a limit, above all of these: compound 2.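

This aromatic carbon, next to the ring nitrogen and next to the ring atom that bears a carboxymethyl group, responds to a change of a single ring atom: in this assay pyridin-4-yl in place of phenyl gives a 3.0-fold lower number from compound 3 to compound 4 (0.48 log units; beyond the scatter) and this modest step lies beyond the scatter. Going by these compounds alone, the earlier compounds offered no pair differing in one place, so this is the first measured sign that the ring here can carry a nitrogen and a hydrogen-bond acceptor without any loss in this read-out. Within the data shown here, nothing measured so far explains why the number falls.

As far as these compounds go, whether the result depends on where the ring nitrogen sits stays open, as pyridin-3-yl and pyridin-2-yl would show, and so does the effect of a phenyl ring carrying an amine. Among these compounds, a single pair also cannot tell whether the same swap would move the number alike beside the other large group, the one that compound 1 carries.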